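The source may hold more compounds than are shown below. What is called first, only, known or untested is meant among the compounds shown, and "the series" means these compounds.

Compound 3 `O=c1ccc2cc(OCc3cn(-c4ccc(Cl)c(Cl)c4)nn3)ccc2o1` was tested in a functional assay on HCT-116 cells (Homo sapiens) for cytotoxicity, read by MTT assay, with a stated time of 48 h; on this read-out lower numbers stand for stronger inhibition and higher numbers for weaker inhibition. In this assay compound 3 gives 57300 nM as its read-out. Compound 1 `O=c1ccc2cc(OCc3cn(-c4ccccc4)nn3)ccc2o1` gives 51500 nM in this assay, and the step of a 1.1-fold higher number from compound 1 to compound 3 (0.05 log units; within the scatter) leaves the two within the scatter of each other. For compound 2 `CC(=O)Nc1ccc(-n2cc(COc3ccc4oc(=O)ccc4c3)nn2)cc1` this assay records "not determined" (no result reported) only. Compound 4 `O=c1ccc2cc(OCc3cn(-c4ccc([N+](=O)[O-])cc4)nn3)ccc2o1` differs from compound 3 in one place: 4-nitrophenyl in place of 3,4-dichlorophenyl on an aromatic nitrogen. Within the data shown here, the only measured step that touches this position, a 1.1-fold higher number from compound 1 to compound 3 (0.05 log units; within the scatter), did not move the number beyond the scatter, so a change on this aromatic nitrogen is expected to leave the read-out essentially where it is; the expected step is a 1.0-fold lower number from compound 3 to compound 4 (0.02 log units; within the scatter). Compound 4 is therefore estimated at 55000 nM in this assay, with a range from 25000 nM to 120000 nM.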

Compound 4, half-maximal inhibitory concentration: 44300 nM
Estimate against measurement, compound 4: 1.2-fold (0.09 log units) above, and the stated range covers the measured number.
By their numbers in this assay, from the lowest: compounds 4, 1 and 3 (each within the scatter of the next).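

In this assay the 4-nitrophenyl group stays within the scatter of both earlier groups, with a 1.3-fold lower number from compound 3 to compound 4 (0.11 log units; within the scatter) and, for nitro in place of hydrogen, a 1.2-fold lower number from compound 1 to compound 4 (0.07 log units; within the scatter) as the two new steps. The aromatic nitrogen has now carried phenyl, 3,4-dichlorophenyl and 4-nitrophenyl, and all three numbers lie within the scatter of one another. Nothing available explains this result. The compounds shown leave open whether an amine or a carboxylic acid on the phenyl ring, or a longer chain in its place, would take the number beyond the scatter.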